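The source may report more compounds than this note shows. Statements on the series, on what has been measured and on what is new or still open speak of the compounds shown alone.

Measured in an ADME assay on MRC5 cells (Homo sapiens) for cytotoxicity, read by fluorescence and resazurin assay, with a stated time of 3 days; a lower number here means that less compound is tolerated, a higher number that more compound is tolerated:
- compound 1 `N#Cc1ccc(OC2CCN(C(=O)Nc3cc(-c4ccccn4)n[nH]3)CC2)cc1`: > 63000 nM
- compound 2 `O=C(Nc1cc(-c2ccccn2)n[nH]1)N1CCN(c2ccc(F)cc2)CC1`: > 64000 nM
- compound 3 `O=C(NCc1cccc(Cl)c1)Nc1cc(-c2ccccn2)n[nH]1`: > 64000 nM

Within the data shown here, all three entries are limits of the assay and not numbers, so the set holds no exact value and no measured step between compounds. Compound 1 stands at the limit of > 63000 nM in this assay, at which 1 of the 3 values shown sits.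

Compound 4 `O=C(Nc1cc(-c2ccccn2)n[nH]1)N1CCC(c2ccc(Cl)cc2)CC1` has not yet been measured. It keeps the core of compound 1 and carries 4-chlorophenyl in place of 4-cyanophenoxy on a saturated ring carbon.

Among the measured compounds shown here, with no measured step to scale from, the expectation rests on the limits alone. Compound 2 differs from compound 1 in its group on the shared core. Compound 2 still gives its limit of > 64000 nM. Compound 3 also carries a different group and likewise gives its limit of > 64000 nM. No step beyond the scatter is therefore expected in this assay, although any real change could only be seen as a lower number, and compound 4 may well return a limit too. The estimated step is an at least 1.1-fold lower number from compound 1 to compound 4 (0.05 log units; that floor lies within the scatter). For compound 4 the expected value is 55000 nM, with an estimated range from 20000 nM to 64000 nM.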

Compound 4, half-maximal cytotoxic concentration: > 62000 nM
Compound 4: a limit, no number; the forecaster's own chance of this, stated with the estimate: 70%; middle value at least 1.1-fold (0.05 log units) from the limit.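

In this assay compound 4 gives > 62000 nM, which is a limit of the assay and not a number. Compound 1 also gives a limit, > 63000 nM, so no step can be read between compound 1 and compound 4. The compounds shown leave open at what concentration any of them would reach the half-maximal cytotoxic read-out, and whether exchanging 4-cyanophenoxy for 4-chlorophenyl changes it at all.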